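Replacing the pyrimidin-2-yl on the sulfur of compound 3

A few compounds are considered here, and "the series" means these few. Any claim that something is new, unique, unknown or untested is made for them only; others in the source may bear on it.

Measured so far in a functional assay on PC-3 cells (Homo sapiens) for inhibition, read by MTT assay, with a stated time of 72 h (on this read-out higher numbers stand for weaker inhibition and lower numbers for stronger inhibition), are these compounds:
- Compound 1 `CC(C)(C)OC(=O)N1CCN(c2cc(C(F)(F)F)nc(SCc3ccc(C(F)(F)F)cc3)n2)CC1` gives 40600 nM as a number
- Compound 2 `FC(F)(F)c1ccc(CSc2nc(N3CCN(c4ncccn4)CC3)cc(C(F)(F)F)n2)cc1` gives > 50000 nM as a limit
- Compound 3 `FC(F)(F)c1ccc(CSc2nc(Sc3ncccn3)cc(C(F)(F)F)n2)cc1` gives > 50000 nM as a limit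

Compound 3 sits at the limit of > 50000 nM in this assay, at which 2 of the 3 values shown sit, and so has no number of its own. Compound 4 `FC(F)(F)c1ccc(CSc2nc(Sc3ncc(-c4ccncc4)s3)cc(C(F)(F)F)n2)cc1` carries 5-(pyridin-4-yl)-1,3-thiazol-2-yl in place of pyrimidin-2-yl on a sulfur, a difference counted as 5-(pyridin-4-yl)-1,3-thiazol-2-yl in place of pyrimidin-2-yl on a sulfur in the two structures.

Within the data shown here, no measured step touches this sulfur. Among the measured compounds shown here, the one measured step, an at least 1.2-fold higher number from compound 1 to compound 2 (0.09 log units; that floor lies within the scatter), lies on an amine nitrogen in a ring and stays within the scatter, so it offers only weak guidance. Compound 1, at 40600 nM, shows that a true number can be read for this family, though still in the high range. In this assay a large step is therefore not expected, only a modest move toward stronger inhibition, and compound 4 may well also end up as a limit. The expected move is an at least 1.3-fold lower number from compound 3 to compound 4 (0.11 log units; that floor lies within the scatter) and this remains an estimate. Compound 4 is estimated at 38000 nM, with an expected range from 15000 nM to 90000 nM in this read-out.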

Compound 4, half-maximal inhibitory concentration: 7350 nM
For compound 4 the middle estimate is 5.2-fold (0.71 log units) above the measured one, and the stated range ends above it.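

Among these compounds, at the sulfur whose other neighbour is an aromatic carbon, exchanging pyrimidin-2-yl for 5-(pyridin-4-yl)-1,3-thiazol-2-yl gives in this assay an at least 6.8-fold lower number from compound 3 to compound 4 (0.83 log units; beyond the scatter) and so, unlike the one earlier step, which lay on an amine nitrogen in a ring and stayed within the scatter, this one clearly registers in the read-out. This shows that the group on this sulfur can move the read-out toward stronger inhibition, something neither compound 2 nor compound 3 could show, since compound 4 gives 7350 nM as a true number. The step can be read only as a floor, because compound 3 has a limit and not a number of its own: the limit of > 50000 nM in this assay, at which 2 of the 4 values shown sit.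

The compounds shown leave open how much of the step belongs to the five-membered ring and how much to the pyridin-4-yl it carries; the two enter together in a single change. An unsubstituted 1,3-thiazol-2-yl, or a phenyl in place of the pyridin-4-yl, would be needed on this sulfur to tell these two parts apart.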